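The compounds below may be only part of what the source reports. "The series", "measured", "known", "first", "only" and "open" are said of these compounds alone.

In a functional assay with Homo sapiens as the target (on this read-out higher numbers stand for weaker inhibition and lower numbers for stronger inhibition), compound 1 `CC(C)[C@H](NC(=O)COc1cccc2ccccc12)C(=O)N[C@@H](CC(=O)O)C(=O)COc1cccc2ccccc12` gives 19000 nM and compound 2 `CC(C)[C@H](NC(=O)COc1cccc2ccccc12)C(=O)N[C@@H](CC(=O)O)C(=O)COc1ccc(F)c(F)c1` gives 16200 nM, so compound 2 stands level with compound 1 within the scatter. Compound 3 `CC(C)[C@H](NC(=O)COc1cccc2ccccc12)C(=O)N[C@@H](CC(=O)O)C(=O)COc1c(Cl)cccc1Cl` is next: 2,6-dichlorophenyl in place of 3,4-difluorophenyl on an oxygen on a saturated carbon. It carries 2,6-dichlorophenyl in place of 3,4-difluorophenyl on an oxygen on a saturated carbon. Within the data shown here, no step beyond the scatter is expected in this assay because a 1.2-fold lower number from compound 1 to compound 2 (0.07 log units; within the scatter) is the only measured step at this place, and one step is thin evidence. The expected step is a 1.1-fold lower number from compound 2 to compound 3 (0.03 log units; within the scatter). For compound 3 the estimate is 15000 nM, with an expected range of 6000 nM to 40000 nM.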

Compound 3, half-maximal inhibitory concentration: 15300 nM
Compound 3: middle estimate off by 1.0-fold (0.01 log units), on the low side, within the range that was stated.
By their numbers in this assay, from the lowest: compounds 3, 2 and 1 (each within the scatter of the next).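

In this assay the step of a 1.1-fold lower number from compound 2 to compound 3 (0.02 log units; within the scatter) and the step of a 1.2-fold lower number from compound 1 to compound 3 (0.09 log units; within the scatter) both stay within the scatter, so 2,6-dichlorophenyl stands level with 3,4-difluorophenyl and naphthalen-1-yl. Among these compounds, on an oxygen on a saturated carbon, three differently substituted aromatic groups now give no separable read-out, and swapping fluorine for chlorine adds no visible step. No measured evidence bears on this flat result. Still open, going by these compounds, is whether a cyclohexyl group, an amine or a longer chain at this place would move the number beyond the scatter.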